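Expected Clearance of Compound 3 After a Ring Swap

The source may report more compounds than this note shows. Statements on the series, on what has been measured and on what is new or still open speak of the compounds shown alone.

Of the compounds shown here, two have so far been measured in an ADME assay on microsomes from liver (Rattus norvegicus) for metabolic stability, read by LC-MS, using NADPH, with stated times of 5 min and 30 min, tested at 1 uM; on this read-out higher numbers stand for fast clearance and lower numbers for slow clearance. Compound 1 `CC(c1ccc2ncc(-c3ccc(F)cc3)cc2c1)n1nnc2ncc(-c3ccncc3)nc21` gives 56 uL/min. Compound 2 `CC(c1ccc2ncc(-c3cnn(C)c3)cc2c1)n1nnc2ncc(-c3ccc(C(N)=O)c(F)c3)nc21` gives 10 uL/min, the lowest of the two numbers, and the gap between compound 2 and compound 1 lies beyond the usual scatter. Compound 3 `CC(c1ccc2ncc(-c3cnn(C)c3)cc2c1)n1nnc2ncc(-c3ccncc3)nc21` has not yet been measured. It differs from compound 2 in one place: pyridin-4-yl in place of 4-carbamoyl-3-fluorophenyl on an aromatic carbon. This change gives compound 3 the same pyridin-4-yl group that compound 1 carries, while the rest of the structure stays as in compound 2. Because compound 1 shows 56 uL/min, a move toward faster clearance is expected, though not all the way to that number. The step of a 2.5-fold higher number from compound 2 to compound 3 (0.40 log units; beyond the scatter) is expected to be upward and of moderate size, probably beyond the scatter. Compound 3 is estimated at 25 uL/min, with a range from 12 uL/min to 50 uL/min.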

Compound 3, intrinsic clearance in a liver preparation (reported as CLH), per the amount of preparation that the assay uses: 61 uL/min
Compound 3: the middle estimate sits 2.4-fold (0.39 log units) below what was measured; the measured number lies above the stated range.
By their numbers in this assay, from the lowest: compound 2; then compounds 1 and 3 (each within the scatter of the next).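

In this assay, pyridin-4-yl in place of 4-carbamoyl-3-fluorophenyl gives a 6.1-fold higher number from compound 2 to compound 3 (0.79 log units; beyond the scatter), so this single swap on the shared core is enough to move the read-out beyond the scatter. With pyridin-4-yl kept, 1-methyl-1H-pyrazol-4-yl in place of 4-fluorophenyl gives a 1.1-fold higher number from compound 1 to compound 3 (0.04 log units; within the scatter), so that second exchange has no effect that can be told apart from the scatter. Nothing shown here identifies what lies behind either result.

As far as these compounds go, whether the slower clearance of compound 2 goes with the carbamoyl group, the fluorine or only the two together remains open, as does how a plain phenyl, a carboxylic acid or an amine would read at this position. From the compounds shown here alone, it is also open whether 4-fluorophenyl and 1-methyl-1H-pyrazol-4-yl would still read alike alongside 4-carbamoyl-3-fluorophenyl.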